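The source may hold more compounds than are shown below. What is called first, only, known or untested is meant among the compounds shown, and "the series" means these compounds.

Going by the values given here, compound 2 `N#Cc1ccc(Cc2cnc(CCc3ccc(-c4ccccc4C(=O)O)cc3)[nH]2)cc1` gives 723 nM in an in vitro functional assay on cells for agonist activity at Bombesin receptor subtype-3 (Mus musculus), read by luminescence and calcium flux (on this read-out higher numbers stand for an effect only at larger amounts of compound and lower numbers for an effect already at smaller amounts), the highest of the two numbers so far; compound 1 `O=C(O)c1ccccc1-c1ccc(CCc2ncc(CC3CCCCC3)[nH]2)cc1` gives 7.3 nM. Among the compounds with values here, the step of a 99-fold higher number from compound 1 to compound 2 (2.00 log units; beyond the scatter) is the only measured change at this position. Compound 3 `O=C(O)c1ccccc1-c1ccc(CCc2ncc(CCc3ccccc3)[nH]2)cc1` carries benzyl in place of 4-cyanophenyl on a saturated chain carbon bound to an aromatic carbon; cut one bond further out, the change reads 4-cyanobenzyl to phenethyl. Within the data shown here, no measured pair isolates the nitrile alone, yet the sole bearing step points toward a lower number once it leaves, so a drop is expected, a 9.0-fold lower number from compound 2 to compound 3 (0.96 log units; beyond the scatter), without a full return to compound 1. Compound 3 is estimated at 80 nM, range 15 nM to 400 nM.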

Compound 3, half-maximal effective concentration: 174 nM
The estimate for compound 3 lay 2.2-fold (0.34 log units) below the measured number, and the stated range covers the measured number.
By their numbers in this assay, from the lowest: compound 1; then compound 3; then compound 2.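

In this assay benzyl in place of 4-cyanophenyl gives a 4.2-fold lower number from compound 2 to compound 3 (0.62 log units; beyond the scatter) at this saturated chain carbon, so the aromatic compounds differ measurably from each other. Benzyl in place of cyclohexyl gives a 24-fold higher number from compound 1 to compound 3 (1.38 log units; beyond the scatter) and leaves compound 3 well above compound 1, so dropping the nitrile and lengthening the chain recovers only part of the gap. No evidence on the cause of either step is available.

The nitrile and the extra chain carbon remain unseparated. As far as these compounds go, whether a piperidine or cyclopentyl ring would match cyclohexyl also stays open.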